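Removing the basic amine from a potent pyrrole carboxamide

The source may hold more compounds than are shown below. What is called first, only, known or untested is meant among the compounds shown, and "the series" means these compounds.

Measured so far: compound 1 `CCN(CC)CCNC(=O)c1ccc(C(CC)(CC)c2ccc(OCC(O)C(C)(C)C)c(C)c2)n1CC`, 220 nM; compound 2 `C#CCNC(=O)c1ccc(C(CC)(CC)c2ccc(OCC(O)C(C)(C)C)c(C)c2)n1CC`, 16200 nM; compound 3 `CCn1c(C(=O)N(C)CC(=O)O)ccc1C(CC)(CC)c1ccc(OCC(=O)C(C)(C)C)c(C)c1`, 18400 nM.

Compound 1 gives the lowest number of the three in a functional assay on PC-3 cells (Homo sapiens), read by MTT assay, with a stated time of 48 h; a higher number here means a weaker inhibitor, a lower number a stronger inhibitor; the others both lie well beyond the scatter above it. The unmeasured compound 4 `CC[C@@H](C)[C@H](NC(=O)c1ccc(C(CC)(CC)c2ccc(OCC(O)C(C)(C)C)c(C)c2)n1CC)C(=O)O` differs from compound 1 in one place: 1-carboxy-2-methylbutyl in place of 2-(diethylamino)ethyl on an amide-type nitrogen. The nearest measured step is a 74-fold higher number from compound 1 to compound 2 (1.87 log units; beyond the scatter), where the 2-(diethylamino)ethyl group also disappears, and compound 3, which carries a carboxylic acid on the amide nitrogen, shows a similarly high number. Compound 4 is therefore expected to follow the same pattern, with a large step upward, a 68-fold higher number from compound 1 to compound 4 (1.83 log units; beyond the scatter), to an estimated 15000 nM (range 4000 nM to 50000 nM).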

Compound 4, half-maximal inhibitory concentration: 1900 nM
Compound 4: the middle estimate sits 7.9-fold (0.90 log units) above what was measured; measured number below the stated range.
By their numbers in this assay, from the lowest: compound 1; then compound 4; then compounds 2 and 3 (each within the scatter of the next).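

In this assay, 1-carboxy-2-methylbutyl on the amide-type nitrogen gives an 8.6-fold higher number from compound 1 to compound 4 (0.94 log units; beyond the scatter), and in place of propargyl it gives an 8.5-fold lower number from compound 2 to compound 4 (0.93 log units; beyond the scatter). Losing 2-(diethylamino)ethyl therefore does not by itself fix the number as high as that of compound 2: what replaces it on this nitrogen matters, although compound 1 remains lowest. Nothing available explains this difference. The compounds shown leave open whether the carboxylic acid or the branched carbon chain goes with the lower number. A plain branched alkyl chain, or an amine in place of the carboxylic acid, would separate the two.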